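The source may report more compounds than this note shows. Statements on the series, on what has been measured and on what is new or still open speak of the compounds shown alone.

Working notes on the series.

Of the compounds shown here, three of the shared core have been measured. Compound 1 `O=C(CCC(=O)c1ccccc1)Nc1nc2ccc(Cl)cc2s1`, compound 2 `O=C(CCC(=O)c1ccccc1)Nc1nc2ccc(F)cc2s1` and compound 3 `O=C(CCC(=O)c1ccccc1)Nc1nc2ccc(Br)cc2s1` differ only in the halogen on the aromatic carbon of the fused ring. In a functional assay on the whole organism with Mus musculus as the target, in the maximal electroshock model, with a stated time of 4 h (on this read-out higher numbers stand for an effect only at larger amounts of compound and lower numbers for an effect already at smaller amounts), compound 1 gives 300 mg/kg, compound 2 gives 300 mg/kg and compound 3 gives 300 mg/kg. The steps are flat: no change at the digits printed from compound 1 to compound 2 (within the scatter), no change at the digits printed from compound 1 to compound 3 (within the scatter) and no change at the digits printed from compound 2 to compound 3 (within the scatter). Compound 3 therefore stands level with compound 1 and compound 2 in this assay, with nothing to separate the three.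

Compound 4 `Cc1ccc2nc(NC(=O)CCC(=O)c3ccccc3)sc2c1` is next, not yet measured in this assay. Its change from compound 3 is methyl in place of bromo on an aromatic carbon. Within the data shown here, no measured step covers methyl; the three halogen exchanges, each without change beyond the scatter, are the only steps that bear on it, and they show the position to be tolerant of exchange at least among halogens. The expected step from compound 3 to compound 4 is no change at the digits printed from compound 3 to compound 4 (within the scatter), with no direction favoured. For compound 4 the estimate in this assay is 300 mg/kg, within a range of 100 mg/kg to 600 mg/kg.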

Compound 4, minimum effective dose: 100 mg/kg
Compound 4: middle estimate off by 3.0-fold (0.48 log units), on the high side, and the stated range covers the measured number.
By their numbers in this assay, from the lowest: compound 4; then compounds 1, 2 and 3 (each within the scatter of the next).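

In this assay this position proves not to be flat: methyl in place of a halogen gives a 3.0-fold lower number from compound 3 to compound 4 (0.48 log units; beyond the scatter) and a 3.0-fold lower number from compound 2 to compound 4 (0.48 log units; beyond the scatter) and a 3.0-fold lower number from compound 1 to compound 4 (0.48 log units; beyond the scatter), each beyond the scatter and all in the same direction. The halogen exchanges alone gave no sign of this, so the first separation at this aromatic carbon appears only when methyl enters, and it points to an effect already at smaller amounts. Nothing at hand explains the step.

The compounds shown leave open whether the gain belongs to methyl alone or extends to ethyl or a longer chain on the same carbon. They also leave open how methoxy or an amine at this place would compare, and how the core with plain hydrogen there would stand against the halogens and methyl.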